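Aminothiophene-carbonitrile series: trifluoromethyl for amino on the aniline

The source may hold more compounds than are shown below. What is called first, only, known or untested is meant among the compounds shown, and "the series" means these compounds.

Measured so far:
- compound 1, `N#Cc1c(Nc2ccc(N)cc2)sc2ccccc12`: 1%
- compound 2, `COc1ccc(Nc2sc3c(OC)cc(OC)cc3c2C#N)cc1`: 63%
- compound 3, `COc1cc2sc(Nc3ccc(O)cc3)c(C#N)c2cc1OC`: 0%

All three were run in a functional assay on HUVEC cells (Homo sapiens), read by fluorescence and microscopy, with a stated time of 6 h, tested at 10 uM; a higher number here means a weaker effect of the compound at the concentration tested, a lower number a stronger effect. Compound 1 gives 1%, the second highest of the three numbers. Its nearest neighbour is compound 3 at 0%, a gap within the usual scatter, so no order between compound 1 and compound 3 can be read. Compound 2 at 63% lies far above both, beyond the scatter. No pair of these compounds differs in one place only, so no single step can be isolated from them.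

The next compound, compound 4, `N#Cc1c(Nc2ccc(C(F)(F)F)cc2)sc2ccccc12`, differs from compound 1 by trifluoromethyl in place of amino on an aromatic carbon.

Among the measured compounds shown here, no measured step covers this change. The only structural hint is that compound 2 with a methoxy on the aniline sits well above compound 1 and compound 3 with their amino and hydroxy, but compound 2 also carries a different core, so this is not a clean comparison. Since compound 1 sits at the floor of the read-out, any step can only be upward. The step from compound 1 to compound 4 is expected to be a number 19 percentage points higher from compound 1 to compound 4 (beyond the scatter), with wide uncertainty. Compound 4 is estimated at 20%, in the range 0% to 65%.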

Compound 4, a percentage reported as activity, at one concentration (the size of the read-out at that concentration, not a potency): 24%
The estimate for compound 4 lay 4 percentage points below the measured number; the range from low to high includes it.
By their numbers in this assay, from the lowest: compounds 3 and 1 (each within the scatter of the next); then compound 4; then compound 2.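

Among the compounds shown here, on the shared core, this is the first single-place step: in this assay, trifluoromethyl in place of amino, on an aromatic carbon para to a large group, gives a number 23 percentage points higher from compound 1 to compound 4 (beyond the scatter). The group at this position therefore matters to the read-out, and the low number of compound 1 does not carry over to every group placed there on the same core. The change alters the heavy-atom count and the hydrogen-bond donors and acceptors together, so this one step cannot separate these differences, and no measurement shown here accounts for the step.

The compounds shown leave open whether the step is specific to trifluoromethyl, as a methyl group, a chlorine atom or a carboxylic acid at the same position on the core of compound 1 would be needed to place it among other replacements of amino. They also leave open whether trifluoromethyl in place of hydroxy on the core of compound 3 would give a step of similar direction and size.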